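The source may report more compounds than this note shows. Statements on the series, on what has been measured and on what is new or still open speak of the compounds shown alone.

Measured so far in an assay on TT cells for inhibition of proto-oncogene tyrosine-protein kinase receptor Ret variant C634W (Homo sapiens), read by MTT assay, with a stated time of 10 days; a higher number here means a weaker inhibitor of growth, a lower number a stronger inhibitor of growth:
compound 1 `CC(C)n1nc(-c2ccon2)c2c(N)ncnc21`: 7920 nM
compound 2 `Nc1ncnc2c1c(-c1cc(C3CC3)on1)nn2C1CCOCC1`: 940 nM

Compound 1 stands highest of the two numbers; compound 2 sits well below it, beyond the scatter, though the two differ in more than one place, so nothing is read from that gap. Compound 3 `CC(C)n1nc(-c2cc(-c3ccc(F)cc3)on2)c2c(N)ncnc21` carries 4-fluorophenyl in place of hydrogen on an aromatic carbon. Within the data shown here, no single-change step is known here, so the size of the step from compound 1 to compound 3 in this assay is guessed: a decrease of moderate size is expected, a 6.6-fold lower number from compound 1 to compound 3 (0.82 log units; beyond the scatter). For compound 3 the estimated value is 1200 nM, with a range from 250 nM to 6000 nM.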

Compound 3, concentration for 50% growth inhibition: > 10000 nM
Compound 3: only a limit was reported; the forecaster's own chance of this, stated with the estimate: 5%; middle value at least 8.3-fold (0.92 log units) from the limit.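

In this assay compound 3 is reported only as a limit of the assay, not as a number: the limit of > 10000 nM in this assay, at which 1 of the 3 values shown sits. Placing 4-fluorophenyl in place of hydrogen on this aromatic carbon, next to the ring oxygen, gives an at least 1.2-fold higher number from compound 1 to compound 3 (0.10 log units; that floor lies within the scatter). As far as these compounds go, this first single-change step at the position therefore brings no lower number, although its true size remains unknown.

The compounds shown leave open how a small group at this carbon, such as methyl or an amine, would read. They also leave open whether an unsubstituted phenyl would behave like 4-fluorophenyl.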